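Swapping Ethoxy for Dimethylamino on the Urea Aryl Ring

The source may report more compounds than this note shows. Statements on the series, on what has been measured and on what is new or still open speak of the compounds shown alone.

Compound 1 `CCOc1ccc(NC(=O)Nc2cccc(CNc3nccnc3Cl)c2)cc1` is tested in a functional assay on T-24 cells (Homo sapiens) for antiproliferative activity, read by MTT assay, with a stated time of 48 h (a lower number here means a stronger inhibitor, a higher number a weaker inhibitor), where compound 1 gives 9080 nM, the lowest of the two numbers shown. Compound 3 `Cc1ccc(NC(=O)Nc2cccc(CNc3nccnc3Cl)c2)c(C)c1` gives 9230 nM in this assay. The step of a 1.0-fold higher number from compound 1 to compound 3 (0.01 log units; within the scatter) stays within the scatter. Compound 2 `O=C(Nc1cccc(CNc2nccnc2Cl)c1)NC1CCCCC1` reaches only a limit of this assay, > 40000 nM. The step of an at least 4.4-fold higher number from compound 1 to compound 2 (0.64 log units; beyond the scatter) is the only one beyond the scatter, and it arises from cyclohexyl in place of 4-ethoxyphenyl.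

Compound 4 `CN(C)c1ccc(NC(=O)Nc2cccc(CNc3nccnc3Cl)c2)cc1` differs from compound 1 by dimethylamino in place of ethoxy on an aromatic carbon. This resembles the change to compound 3, which stayed within the scatter, rather than the change to compound 2. The expected step is therefore a 1.0-fold lower number from compound 1 to compound 4 (0.00 log units; within the scatter), none beyond the scatter. Compound 4 is estimated at 9000 nM, within 4500 nM to 18000 nM.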

Compound 4, half-maximal inhibitory concentration: 20200 nM
The estimate for compound 4 lay 2.2-fold (0.35 log units) below the measured number; measured number outside the range, above it.
By their numbers in this assay, from the lowest: compounds 1 and 3 (each within the scatter of the next); then compound 4. At a limit, above all of these: compound 2.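

The position para to a large group is sensitive to more than group size in this assay: dimethylamino in place of ethoxy on an aromatic carbon, with the same count of heavy atoms, gives a 2.2-fold higher number from compound 1 to compound 4 (0.35 log units; beyond the scatter). Compound 4 also separates from the 2,4-dimethylphenyl compound, with a 2.2-fold higher number from compound 3 to compound 4 (0.34 log units; beyond the scatter), so having an aromatic ring on the urea does not alone set the number. The step of an at least 1.9-fold lower number from compound 2 to compound 4 (0.29 log units; that floor lies within the scatter) cannot be read as a firm difference. Compound 2 stands at a limit: the limit of > 40000 nM in this assay, at which 1 of the 4 values shown sits.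

Going by these compounds, it remains open whether a methoxy group, a longer propoxy chain or a free amine at this position would track compound 1 or compound 4.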